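The source may report more compounds than this note shows. Statements on the series, on what has been measured and on what is new or still open speak of the compounds shown alone.

Compound 3 `O=C1c2ccccc2S(=O)(=O)N1CCCCCN1CCN(c2cccc(Cl)c2Cl)CC1` gives 149 nM in an assay on HEK293 cells for displacement of a labelled ligand from 5-hydroxytryptamine receptor 7 (Homo sapiens) (a higher number here means a weaker inhibitor, a lower number a stronger inhibitor), the lowest of the three numbers; compound 1 `O=C1c2ccccc2S(=O)(=O)N1CCCCCN1CCN(c2ccc(Cl)cc2)CC1` sits nearest, at 191 nM, and compound 2 `O=C1c2ccccc2S(=O)(=O)N1CCCCCN1CCN(c2ncccn2)CC1` furthest, at 2670 nM. Within these three, a 1.3-fold lower number from compound 1 to compound 3 (0.11 log units; within the scatter), whereas a 14-fold higher number from compound 1 to compound 2 (1.15 log units; beyond the scatter) and an 18-fold lower number from compound 2 to compound 3 (1.25 log units; beyond the scatter). Compound 4 `O=C1c2ccccc2S(=O)(=O)N1CCCCCN1CCN(c2cccc3ccccc23)CC1` differs from compound 3 by naphthalen-1-yl in place of 2,3-dichlorophenyl on an amine nitrogen in a ring. Within the data shown here, no measured step swaps one aromatic carbocycle for a larger one; the two large steps each involve pyrimidin-2-yl, and the single exchange between two chlorophenyl groups stayed within the scatter. A step of similar small size is therefore expected in this assay, a 1.2-fold lower number from compound 3 to compound 4 (0.09 log units; within the scatter). Compound 4 is estimated at 120 nM, with a range from 35 nM to 400 nM.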

Compound 4, inhibition constant: 36 nM
Estimate against measurement, compound 4: 3.3-fold (0.52 log units) above; the measured number falls inside the stated range.
By their numbers in this assay, from the lowest: compound 4; then compounds 3 and 1 (each within the scatter of the next); then compound 2.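

In this assay the naphthalen-1-yl group on the amine nitrogen in a ring stands apart from both chlorophenyl groups (a 4.1-fold lower number from compound 3 to compound 4 (0.62 log units; beyond the scatter)) and (a 5.3-fold lower number from compound 1 to compound 4 (0.72 log units; beyond the scatter)), although those two groups lie within the scatter of each other. The distance from the pyrimidin-2-yl group also grows (a 74-fold lower number from compound 2 to compound 4 (1.87 log units; beyond the scatter)), so this position accepts 2 six-membered aromatic rings of carbon only, with the lowest number of the four.

As far as these compounds go, whether this holds for a naphthalen-2-yl group, an unsubstituted phenyl group or a longer chain remains open. Nothing available explains these steps.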